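One Methyl, Two Cores: Antiproliferative Activity on HepG2 Cells

The source may report more compounds than this note shows. Statements on the series, on what has been measured and on what is new or still open speak of the compounds shown alone.

Compound 1 `COc1cc(CC(O)(COCc2ccccc2)COCc2ccccc2)nc(OC)n1` was tested in a functional assay on HepG2 cells (Homo sapiens) for antiproliferative activity, read by MTT assay, with a stated time of 72 h; a higher number here means a weaker inhibitor, a lower number a stronger inhibitor. In this assay compound 1 gives > 100000 nM, which is a limit of the assay and not a number. Compound 2 `COc1nc(CC(O)(COCc2ccccc2)COCc2ccccc2)c(C)c(OC)n1` carries the change methyl in place of hydrogen on an aromatic carbon and in this assay compound 2 gives 2400 nM. The step of an at least 41-fold lower number from compound 1 to compound 2 (1.61 log units; beyond the scatter) is the only measured step among these compounds. Compound 3 `O=c1cc(CC(O)COCc2ccccc2)[nH]c(=O)[nH]1` rests on a different core; the difference between the two cores is not broken down here. In this assay compound 3 gives > 100000 nM, again a limit rather than a number. Two of the three values sit at the limit of > 100000 nM in this assay, at which 2 of the 3 values shown sit.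

Compound 4 `Cc1c(CC(O)COCc2ccccc2)[nH]c(=O)[nH]c1=O` has not yet been measured and differs from compound 3 by methyl in place of hydrogen on an aromatic carbon. This is the same kind of change as that from compound 1 to compound 2, but the surroundings differ: in compound 4 the methyl stands ortho to a group of 1 heavy atom and para to a group of 1 heavy atom, whereas in compound 2 it stands ortho to a methoxy group (2 heavy atoms) and para to a methoxy group (2 heavy atoms). Among the compounds with values here, the one measured step of an at least 41-fold lower number from compound 1 to compound 2 (1.61 log units; beyond the scatter) rests on a single pair and on a different core. For compound 4 a smaller step of an at least 3.3-fold lower number from compound 3 to compound 4 (0.52 log units; beyond the scatter) is therefore expected in this assay. Compound 4 is estimated at 30000 nM in this assay, with a range from 4000 nM to 100000 nM.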

Compound 4, half-maximal inhibitory concentration: > 100000 nM
Compound 4 was reported as a limit (the forecaster's own chance of this, stated with the estimate: 45%); at least 3.3-fold (0.52 log units) between middle value and limit.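

In this assay, within the data shown here, compound 3 and compound 4 both stand at a limit of the assay and not at a number, so no step between them can be read: the limit of > 100000 nM in this assay, at which 3 of the 4 values shown sit.

The compounds shown leave open whether methyl in place of hydrogen on an aromatic carbon changes the result at all on the core of compound 3, below that limit.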